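A few compounds are considered here, and "the series" means these few. Any claim that something is new, unique, unknown or untested is made for them only; others in the source may bear on it.

In an assay on L cells for inhibition of Protein-serine O-palmitoleoyltransferase porcupine (Mus musculus), read by reporter gene assay, with a stated time of 24 h (on this read-out higher numbers stand for an effect only at larger amounts of compound and lower numbers for an effect already at smaller amounts), the measured compounds are:
Compound 1, `O=C(CSc1nc2c(c(=O)n1-c1ccccc1)SCC2)Nc1cccc(-c2ccccc2)c1`, gives > 5000 nM, which is a limit of the assay and not a number.
Compound 2, `O=C(CSc1nc2c(c(=O)n1-c1ccccc1)SCC2)Nc1ccc(-c2ccoc2)cn1`, gives 1.5 nM.
Compound 3, `O=C(CSc1nc2c(c(=O)n1-c1ccccc1)SCC2)Nc1ccc(-c2ccco2)cn1`, gives 3.5 nM.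

Among the two numbers shown, compound 3 stands highest, with compound 2 the nearest and lower. Within the data shown here, the only measured step is a 2.3-fold higher number from compound 2 to compound 3 (0.37 log units; beyond the scatter), a swap of one furan for the other. Compound 4, `O=C(CSc1nc2c(c(=O)n1-c1ccccc1)SCC2)Nc1ccc(-c2cccnc2)cn1`, differs from compound 3 in this way: pyridin-3-yl in place of furan-2-yl on an aromatic carbon. Among the measured compounds shown here, no measured step exchanges a five-membered ring for a six-membered one here, so the furan swap is the closest guide, and it was modest. Compound 4 is therefore expected near 6 nM, between 1.5 nM and 25 nM, meaning an expected step of a 1.7-fold higher number from compound 3 to compound 4 (0.23 log units; within the scatter), near the edge of the scatter.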

Compound 4, half-maximal effective concentration: 1 nM
Compound 4: middle estimate off by 6.0-fold (0.78 log units), on the high side; measured number below the stated range.
By their numbers in this assay, from the lowest: compounds 4 and 2 (each within the scatter of the next); then compound 3. At a limit, above all of these: compound 1.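

Pyridin-3-yl in place of furan-2-yl gives a 3.5-fold lower number from compound 3 to compound 4 (0.54 log units; beyond the scatter) and so shows that this position accepts a six-membered aromatic ring as well as a five-membered one, with no loss in the read-out. Set against the other furan, the same ring gives a 1.5-fold lower number from compound 2 to compound 4 (0.18 log units; within the scatter) and so compound 2 and compound 4 cannot be told apart. From the compounds shown here alone, whether this position would also accept a piperidine ring, or a pyridine carrying an amine or a carboxylic acid, stays open. Nothing in the data shown explains why these ring changes move the number as they do.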